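Working notes: iodo for ethoxy on the shared core

A few compounds are considered here, and "the series" means these few. Any claim that something is new, unique, unknown or untested is made for them only; others in the source may bear on it.

Measured so far:
Compound 1 `COc1cc(C(=O)c2sc(-c3ccc(Cl)cc3)cc2N)cc(OC)c1OC` — 70 nM
Compound 2 `COc1cc(C(=O)c2sc(-c3ccc(F)cc3)cc2N)cc(OC)c1OC` — 15 nM
Compound 3 `CCOc1ccc(-c2cc(N)c(C(=O)c3cc(OC)c(OC)c(OC)c3)s2)cc1` — 270 nM

In a functional assay on CCRF-CEM cells (Homo sapiens) for antiproliferative activity (on this read-out higher numbers stand for weaker inhibition and lower numbers for stronger inhibition), compound 3 gives the highest of the three numbers; the closest is compound 1, and compound 2 is furthest away. Compound 4 `COc1cc(C(=O)c2sc(-c3ccc(I)cc3)cc2N)cc(OC)c1OC` is not yet measured and differs from compound 3 in one place: iodo in place of ethoxy on an aromatic carbon.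

Going by the values given here, two measured steps bear on this change, since both replace a halogen on the same aromatic carbon with the ethoxy group: a 3.9-fold higher number from compound 1 to compound 3 (0.59 log units; beyond the scatter) and an 18-fold higher number from compound 2 to compound 3 (1.26 log units; beyond the scatter). Read in reverse, both say that removing the ethoxy in favour of a halogen brings the number down, modestly for chloro and by a large amount for fluoro. Among the compounds with values here, compound 1 and compound 2 together show that the smaller halogen gave the lower number, and iodo is the largest of the three; no iodo compound has been measured, so the size is uncertain. A modest downward step is therefore expected for compound 4, a 2.7-fold lower number from compound 3 to compound 4 (0.43 log units; beyond the scatter), closer to the chloro case than to the fluoro case. Compound 4 is estimated at 100 nM, with a range from 30 nM to 350 nM.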

Compound 4, half-maximal inhibitory concentration: 150 nM
Estimate against measurement, compound 4: 1.5-fold (0.18 log units) below; low and high end bracket the measured number.
By their numbers in this assay, from the lowest: compound 2; then compound 1; then compounds 4 and 3 (each within the scatter of the next).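

In this assay, iodo and ethoxy cannot be told apart at this place, para to a large group, with a 1.8-fold lower number from compound 3 to compound 4 (0.26 log units; within the scatter) despite one heavy atom entering and three leaving. Compound 4 also extends the halogen comparison, with the number rising in the order fluoro, chloro, iodo across compounds 2, 1 and 4: the chloro-to-iodo change gives a 2.1-fold higher number from compound 1 to compound 4 (0.33 log units; beyond the scatter) and the fluoro-to-iodo change gives a 10-fold higher number from compound 2 to compound 4 (1.00 log units; beyond the scatter) as the full span. No measurement on hand accounts for this order or for the match between iodo and ethoxy.

Open, going by these compounds, is whether bromo falls within the same order, and how a hydrogen, an amine or a carboxylic acid would read at this place. Also open, on these data alone, is whether methoxy or a longer alkoxy chain would read like ethoxy.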